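The source may hold more compounds than are shown below. What is called first, only, known or untested is meant among the compounds shown, and "the series" means these compounds.

For the measured compounds named here, in an ADME assay on HepG2 2.2.15 cells (Homo sapiens) for cytotoxicity, read by luminescence, with a stated time of 3 days (on this read-out higher numbers stand for lower toxicity in this test and lower numbers for higher toxicity in this test), compound 1 `O=C(Nc1ccc(F)c(Cl)c1)c1ccc(F)c(S(=O)(=O)N2CCCCCC(O)C2)c1` gives 11000 nM, the lower of the two numbers measured so far, while compound 2 `O=C(Nc1ccc(F)c(Cl)c1)c1ccc(F)c(S(=O)(=O)N2CCCCC(O)CC2)c1` gives 24000 nM. Compound 1 therefore stands at the more toxic end of this small set. Compound 3 `O=C(Nc1ccc(F)c(Cl)c1)c1ccc(F)c(S(=O)(=O)N2CCCCCCC2O)c1` has the same atoms as compound 1, joined differently, and the change sits on a sulfonyl sulfur: a group of 9 heavy atoms (7 carbon, 1 nitrogen, 1 oxygen; one eight-membered non-aromatic ring with 1 hetero atom) in place of a group of 9 heavy atoms (7 carbon, 1 nitrogen, 1 oxygen; one eight-membered non-aromatic ring with 1 hetero atom), on a sulfonyl sulfur. Going by the values given here, only one measured step bears on this exchange, also a swap of one such eight-membered group for another: a 2.2-fold higher number from compound 1 to compound 2 (0.34 log units; beyond the scatter). That modest step is a single example, and it cannot fix a direction for the new group with confidence. Among the compounds with values here, a small move to a higher number in this assay is expected, no larger than that step, and the estimated change is a 1.5-fold higher number from compound 1 to compound 3 (0.19 log units; within the scatter). For compound 3 the estimated value is 17000 nM, with an expected range from 7000 nM to 40000 nM.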

Compound 3, half-maximal cytotoxic concentration: 7000 nM
Estimate against measurement, compound 3: 2.4-fold (0.39 log units) above; the measured number falls inside the stated range.
By their numbers in this assay, from the lowest: compounds 3 and 1 (each within the scatter of the next); then compound 2.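

Within this assay, exchanging one eight-membered group for another on the sulfonyl sulfur does not always move the read-out: the step of a 1.6-fold lower number from compound 1 to compound 3 (0.20 log units; within the scatter) stays inside the usual scatter, whereas the step of a 3.4-fold lower number from compound 2 to compound 3 (0.54 log units; beyond the scatter) lies beyond it. How the same atoms are joined within this group can therefore matter, with compound 2 standing apart from compound 3 while compound 1 and compound 3 cannot be told apart here. No measurement offered with these compounds explains this difference.

The compounds shown leave open whether the hydroxyl itself is needed for this spread, which a methoxy or an amine on the same ring would test. They also leave open whether the spread persists on a smaller ring such as piperidine.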